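The compounds below may be only part of what the source reports. "The series", "measured", "known", "first", "only" and "open" are said of these compounds alone.

Measured so far:
compound 1, `CC(C)Nc1nc(NCc2ccco2)c2ccccc2n1`: >= 30000 nM
compound 2, `OCCNc1nc(NCc2ccco2)c2ccccc2n1`: <= 20000 nM

In a physicochemical assay for solubility, at pH 7.4 (on this read-out higher numbers stand for higher solubility and lower numbers for lower solubility), compound 1 gives >= 30000 nM; this is a limit of the assay, not a number, as noted in the limit of >= 30000 nM in this assay, at which 1 of the 2 values shown sits. Compound 2 gives <= 20000 nM, likewise a limit, recorded in the limit of <= 20000 nM in this assay, at which 1 of the 2 values shown sits. Within the data shown here, the one measured step is an at least 1.5-fold lower number from compound 1 to compound 2 (0.17 log units; that floor lies within the scatter), with 2-hydroxyethyl in place of isopropyl on a nitrogen on an aromatic ring; only its floor is known, and that floor lies within the scatter.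

Compound 3, `CSCCNc1nc(NC(C)C)nc2ccccc12`, is reached from compound 1 by (methylsulfanyl)methyl in place of furan-2-yl on a saturated chain carbon bound to a nitrogen on an aromatic ring. Among the measured compounds shown here, this change sits at a different place from the measured step, so that step gives no guide here, and no measured pair touches a saturated chain carbon bound to a nitrogen on an aromatic ring. In this assay no step beyond the scatter is therefore expected in either direction; the expected step is a number no higher from compound 1 to compound 3 (the limit leaves the size open). Compound 3 is estimated at 30000 nM, in the range 10000 nM to 100000 nM, with a limit reading again likely.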

Compound 3, solubility: <= 20000 nM
Compound 3 gave a limit, no number (the forecaster's own chance of this, stated with the estimate: 60%); at least 1.5-fold (0.17 log units) between middle value and limit.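

In this assay compound 3 gives <= 20000 nM, a limit of the assay and not a number. Among these compounds, this is the first reading on a saturated chain carbon bound to a nitrogen on an aromatic ring: with (methylsulfanyl)methyl in place of furan-2-yl, the step is an at least 1.5-fold lower number from compound 1 to compound 3 (0.17 log units; that floor lies within the scatter), so only its floor is known. The change at this place therefore ends on the same limit as the earlier change on the other side of the shared core: the limit of <= 20000 nM in this assay, at which 2 of the 3 values shown sit.

From the compounds shown here alone, since both ends of the step are limits, its true size remains open, and it may lie within the scatter or well beyond it. Also open, going by these compounds, is how a carboxylic acid, an amine or a longer chain on this same carbon would read in this assay.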